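Moving the methyl on the phenyl at the chain carbon

This account rests on a few compounds, and the source may have more. Where it says the series, first, only, none or still open, it means among the compounds named here.

Measured compounds:
compound 1, `COc1ccccc1N1CCN(CCCOc2ccc(C(=O)Nc3ccccc3OCCCC(=O)O)cc2)CC1`, 100 nM
compound 2, `COc1ccccc1N1CCN(CCC(Oc2ccc(C(=O)Nc3ccccc3OCCCC(=O)O)cc2)c2ccccc2)CC1`, 25.1 nM
compound 3, `COc1ccccc1N1CCN(CCC(Oc2ccc(C(=O)Nc3ccccc3OCCCC(=O)O)cc2)c2cccc(C)c2)CC1`, 251 nM

In an assay on Prostate gland (Oryctolagus cuniculus) for inhibition of Adrenergic receptor alpha-1 (Homo sapiens) (a lower number here means tighter binding, a higher number weaker binding), compound 3 gives the highest number of the three. Compound 1 sits nearest to it, and compound 2 furthest; the gaps are a 2.5-fold higher number from compound 1 to compound 3 (0.40 log units; beyond the scatter) and a 10-fold higher number from compound 2 to compound 3 (1.00 log units; beyond the scatter).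

Compound 4 is `COc1ccccc1N1CCN(CCC(Oc2ccc(C(=O)Nc3ccccc3OCCCC(=O)O)cc2)c2ccc(C)cc2)CC1`. It differs from compound 3 in one place: 4-methylphenyl in place of 3-methylphenyl on a saturated chain carbon bound to an oxygen on an aromatic ring and a saturated chain carbon. The two compounds share every atom and differ only in where the methyl sits on the phenyl.

Among the compounds with values here, no measured step moves a methyl from one ring position to another, so the bearing evidence is indirect. Putting a phenyl on the chain carbon gave a 4.0-fold lower number from compound 1 to compound 2 (0.60 log units; beyond the scatter), while adding a methyl to that phenyl gave a 10-fold higher number from compound 2 to compound 3 (1.00 log units; beyond the scatter), and the two changes taken together amount to a 2.5-fold higher number from compound 1 to compound 3 (0.40 log units; beyond the scatter). Whether a 4-methylphenyl behaves like the 3-methylphenyl of compound 3 or like the plain phenyl of compound 2 cannot be read from these data. Compound 4 is therefore expected to fall between the two, with a 2.1-fold lower number from compound 3 to compound 4 (0.32 log units; beyond the scatter) as the estimated step. For compound 4 the estimate in this assay is 120 nM, with a range from 30 nM to 500 nM.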

Compound 4, dissociation constant: 15.9 nM
The estimate for compound 4 lay 7.5-fold (0.88 log units) above the measured number, and the stated range ends above it.
By their numbers in this assay, from the lowest: compounds 4 and 2 (each within the scatter of the next); then compound 1; then compound 3.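

In this assay, the position of the methyl on the phenyl proves decisive, since moving it alone gives a large change (a 16-fold lower number from compound 3 to compound 4 (1.20 log units; beyond the scatter)) although the two compounds share every atom. The 4-methylphenyl stays within the scatter of the plain phenyl (a 1.6-fold lower number from compound 2 to compound 4 (0.20 log units; within the scatter)), so the loss seen with the 3-methylphenyl does not follow from adding a methyl to this ring as such. The gain from a ring on the chain carbon also holds with the 4-methylphenyl (a 6.3-fold lower number from compound 1 to compound 4 (0.80 log units; beyond the scatter)), and nothing available explains the gap between the two methylphenyl groups.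

As far as these compounds go, whether a 4-chlorophenyl or a 4-methoxyphenyl would behave like the 4-methylphenyl remains open. From the compounds shown here alone, it is also open whether the same gap between the two methylphenyl groups would persist with an ester in place of the carboxylic acid.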